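The compounds below may be only part of what the source reports. "The series", "measured", "known", "first", "only" and "open" are said of these compounds alone.

Measured compounds, with their numbers in a functional assay on B16 cells (Mus musculus) for cytotoxicity, read by MTT assay, with a stated time of 72 h; on this read-out lower numbers stand for stronger inhibition and higher numbers for weaker inhibition:
- compound 1, `O=c1cc(-c2ccccc2)oc2c(OCCCN3CCCC3)c(OCc3ccccc3)cc(O)c12`: 7980 nM
- compound 2, `CN1CCN(CCCOc2c(OCc3ccccc3)cc(O)c3c(=O)cc(-c4ccccc4)oc23)CC1`: 3760 nM
- compound 3, `CN(C)CCCCOc1c(OCc2ccccc2)cc(O)c2c(=O)cc(-c3ccccc3)oc12`: 3220 nM

Compound 3 has the lowest number of the three, but its gap to compound 2 is within the scatter, so the two cannot be ordered; only compound 1 sits apart, as a 2.5-fold lower number from compound 1 to compound 3 (0.39 log units; beyond the scatter) shows, alongside a 2.1-fold lower number from compound 1 to compound 2 (0.33 log units; beyond the scatter) and a 1.2-fold lower number from compound 2 to compound 3 (0.07 log units; within the scatter).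

Compound 4, `CCN(CC)CCCCOc1c(OCc2ccccc2)cc(O)c2c(=O)cc(-c3ccccc3)oc12`, differs from compound 3 in one place: diethylamino in place of dimethylamino on a saturated chain carbon, four bonds along the chain from an oxygen on an aromatic ring. Among the measured compounds shown here, no measured step swaps one acyclic amine for another of this kind; the steps that bear on it are the amine changes above, which ran from modest to within the scatter, and the two acyclic amines of compounds 2 and 3 sit together. A step within the scatter is therefore expected in this assay, with no clear direction, giving a 1.0-fold lower number from compound 3 to compound 4 (0.00 log units; within the scatter) as the expected change. For compound 4 the estimate in this assay is 3200 nM, with a range from 1500 nM to 7000 nM.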

Compound 4, half-maximal inhibitory concentration: 4880 nM
The estimate for compound 4 lay 1.5-fold (0.18 log units) below the measured number; low and high end bracket the measured number.
By their numbers in this assay, from the lowest: compounds 3, 2, 4 and 1 (each within the scatter of the next, the first and the last beyond it).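

Diethylamino in place of dimethylamino, on a saturated chain carbon four bonds along the chain from an oxygen on an aromatic ring, is the first swap of one acyclic amine for another in this assay, and with a 1.5-fold higher number from compound 3 to compound 4 (0.18 log units; within the scatter) the two compounds cannot be ordered. Nor does the 4-methylpiperazin-1-yl compound separate from the diethylamino compound, given a 1.3-fold higher number from compound 2 to compound 4 (0.11 log units; within the scatter). The pyrrolidin-1-yl compound no longer stands fully apart: its steps to compound 2 and compound 3 lie beyond the scatter, but a 1.6-fold lower number from compound 1 to compound 4 (0.21 log units; within the scatter) does not, so the four numbers form a continuous run.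

No evidence here accounts for these numbers. Going by these compounds, how dipropylamino, piperidin-1-yl or morpholin-4-yl would read at this place remains open, as does a longer chain carrying diethylamino.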